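The source may hold more compounds than are shown below. What is called first, only, known or untested is meant among the compounds shown, and "the series" means these compounds.

Working notes on the series, read in a functional assay on the whole organism (Ear) for inhibition, with Mus musculus as the target, with a stated time of 30 min, at a dose of 50 mg/kg by the intraperitoneal route; a lower number here means less inhibition, a higher number more inhibition at the dose given (going by the name of the read-out). For the measured compounds named here, compound 1 `N=C(N)N/N=C/c1cn(-c2ccc([N+](=O)[O-])cc2[N+](=O)[O-])nc1-c1cccc(Br)c1` gives 81.7%, and compound 2 `N=C(N)N/N=C/c1cn(-c2ccc([N+](=O)[O-])cc2[N+](=O)[O-])nc1-c1ccc(Br)cc1` gives 69.6%; the only single change measured is a number 12.1 percentage points lower from compound 1 to compound 2 (beyond the scatter). Compound 3 `N=C(N)N/N=C/c1cn(-c2ccccc2)nc1-c1ccc(Br)cc1` gives 42.8%, the lowest of the three numbers, beyond the scatter under compound 2 and further still under compound 1. Compound 4 `N=C(N)N/N=C/c1cn(-c2ccccc2)nc1-c1cccc(Cl)c1` is not yet measured and differs from compound 3 by 3-chlorophenyl in place of 4-bromophenyl on an aromatic carbon. Going by the values given here, the one measured step, 4-bromophenyl in place of 3-bromophenyl, was modest and downward; the present change runs the other way in ring position but swaps bromine for chlorine, on which nothing has been measured, so only a modest rise is anticipated. Compound 4 is expected to give 52%, in the range 36% to 68%. The step of a number 9.2 percentage points higher from compound 3 to compound 4 (within the scatter) is thus the expected size.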

Compound 4, a percentage reported as inhibition, in the whole organism at one dose (the size of the read-out at that dose, not a potency): 93.6%
For compound 4 the middle estimate is 41.6 percentage points below the measured one; the measured number lies above the stated range.
By their numbers in this assay, from the lowest: compound 3; then compound 2; then compound 1; then compound 4.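

In this assay the swap of 4-bromophenyl for 3-chlorophenyl on this aromatic carbon gives a number 50.8 percentage points higher from compound 3 to compound 4 (beyond the scatter), a large step where the earlier move of bromine alone gave the modest a number 12.1 percentage points lower from compound 1 to compound 2 (beyond the scatter). In both steps the 3-halophenyl compound holds the higher number, although the new step also exchanges bromine for chlorine and the two pairs carry different groups on the ring nitrogen. Nothing at hand explains the size of the step.

The compounds shown leave open how much of the step belongs to ring position and how much to the halogen. Also open, going by these compounds, is how a 3-methoxyphenyl or 3-aminophenyl group would read at this carbon.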